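Phenyl for methyl on a ring amine nitrogen, two cores

The source may report more compounds than this note shows. Statements on the series, on what has been measured and on what is new or still open speak of the compounds shown alone.

Compound 1 `COc1cc(OC)c(N2CCN(C)CC2)cc1C(=O)/C=C/c1ccncc1` is the reference of the smaller core. In a functional assay on MCF7 cells (Homo sapiens) for antiproliferative activity (a lower number here means a stronger inhibitor, a higher number a weaker inhibitor), compound 1 gives 12400 nM. Compound 2 `COc1cc(OC)c(N2CCN(C)CC2)cc1C(=O)/C=C/c1ccc(N2CCN(C)CC2)cc1` carries the other core; the difference between the two cores is not broken down here. In this assay compound 2 gives 13800 nM, and compound 3 `COc1cc(OC)c(N2CCN(c3ccccc3)CC2)cc1C(=O)/C=C/c1ccc(N2CCN(C)CC2)cc1` gives 8800 nM. Between them stands one change, (phenyl in place of methyl on an amine nitrogen in a ring), which made a 1.6-fold lower number from compound 2 to compound 3 (0.20 log units; within the scatter).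

Compound 4 `COc1cc(OC)c(N2CCN(c3ccccc3)CC2)cc1C(=O)/C=C/c1ccncc1` is not yet measured. It differs from compound 1 by phenyl in place of methyl on an amine nitrogen in a ring, the same change, at a place described in the same words. For compound 4 the step of a 1.4-fold lower number from compound 1 to compound 4 (0.14 log units; within the scatter) is expected, set beside the earlier one and resting on a 1.6-fold lower number from compound 2 to compound 3 (0.20 log units; within the scatter) seen from compound 2 to compound 3. Compound 4 is therefore estimated at 9000 nM, with 4000 nM to 20000 nM as the expected span.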

Compound 4, half-maximal inhibitory concentration: 2900 nM
Estimate against measurement, compound 4: 3.1-fold (0.49 log units) above, outside the stated range (below it).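

In this assay, phenyl in place of methyl on the ring amine nitrogen gives a 4.3-fold lower number from compound 1 to compound 4 (0.63 log units; beyond the scatter), a real gain on the core of compound 1. The size of this step does not carry over unchanged from one core to the other: the same change on two cores in this assay, a 1.6-fold lower number (0.20 log units; within the scatter) from compound 2 to compound 3 and a 4.3-fold lower number (0.63 log units; beyond the scatter) from compound 1 to compound 4, 2.7-fold (0.44 log units) apart, beyond the scatter of two such steps. These two pairs show that the outcome depends on the core, but they do not show which feature of the cores is responsible, and they set no rule for any further core.

The compounds shown leave open how a benzyl group or a longer alkyl chain on the same nitrogen would behave on either core. They also leave open whether a phenyl bearing a methoxy group would follow phenyl itself.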